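This account rests on a few compounds, and the source may have more. Where it says the series, first, only, none or still open, it means among the compounds named here.

Going by the values given here, in a functional assay for inhibition, with Rattus norvegicus as the target (on this read-out higher numbers stand for weaker inhibition and lower numbers for stronger inhibition), compound 1 `CC(C)(C)c1cc(/C=C2\CCNC2=O)cc(C(C)(C)C)c1O` gives 50000 nM and compound 2 `CCN1CC/C(=C\c2cc(C(C)(C)C)c(O)c(C(C)(C)C)c2)C1=O` gives 30 nM, the lower of the two numbers so far. Among the compounds with values here, the single measured step, a 1700-fold lower number from compound 1 to compound 2 (3.22 log units; beyond the scatter), is large and beyond the scatter. It came with ethyl in place of hydrogen on an amide-type nitrogen in a ring.

Compound 3 `CC(=O)N1CC/C(=C\c2cc(C(C)(C)C)c(O)c(C(C)(C)C)c2)C1=O` keeps the shared core and changes that same nitrogen, with acetyl in place of ethyl on an amide-type nitrogen in a ring. Within the data shown here, no measured compound carries acetyl there, so the one step is the only guide, and it shows how much this nitrogen can matter in this assay. The nitrogen stays substituted in compound 3, so a full return towards compound 1 at 50000 nM is not expected. A moderate move to a higher number is expected instead, clearly smaller than a 1700-fold lower number from compound 1 to compound 2 (3.22 log units; beyond the scatter), though the uncertainty is wide. The estimate is a 10-fold higher number from compound 2 to compound 3 (1.00 log units; beyond the scatter). The expected value for compound 3 is 300 nM, with an estimated range of 30 nM to 5000 nM.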

Compound 3, half-maximal inhibitory concentration: 200 nM
Estimate against measurement, compound 3: 1.5-fold (0.18 log units) above, within the range that was stated.
By their numbers in this assay, from the lowest: compound 2; then compound 3; then compound 1.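

In this assay, the large drop is no longer tied to ethyl alone: acetyl in place of hydrogen on the amide-type nitrogen in a ring gives a 250-fold lower number from compound 1 to compound 3 (2.40 log units; beyond the scatter), so both substituted compounds, compound 2 and compound 3, sit far below compound 1. The choice of substituent still registers, though on a smaller scale: acetyl in place of ethyl gives a 6.7-fold higher number from compound 2 to compound 3 (0.82 log units; beyond the scatter), a modest step that is beyond the scatter, so among these three compounds most of the change goes with replacing the hydrogen, and a smaller part with which group replaces it. Nothing available here bears on the reason for either step.

The three compounds leave open whether the difference between ethyl and acetyl follows the carbonyl of the acetyl group or its one additional heavy atom, and a propionyl or a methyl group on the same nitrogen would bear on that. Going by these compounds, it also remains open how far this nitrogen tolerates larger or differently built groups, such as a butyl chain, a benzyl group, or a chain ending in an amine or a carboxylic acid.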